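The compounds below may be only part of what the source reports. "The series", "measured", "known", "first", "only" and "open" are said of these compounds alone.

Compound 1, `CCCCCCNC(=O)n1cc(F)c(=O)n(CC2CC2)c1=O`, gives 61 nM in an assay on HEK293 cells for inhibition of acid ceramidase (Rattus norvegicus), read by LC-MS, with a stated time of 30 min; on this read-out higher numbers stand for weaker inhibition and lower numbers for stronger inhibition.
Compound 2, `CCCCCCNC(=O)n1cc(F)c(=O)n(C(=O)C(C)C)c1=O`, gives 21 nM in this assay.
Compound 3, `CCCCCCNC(=O)n1cc(F)c(=O)n(C(=O)OCC)c1=O`, gives 12 nM in this assay.

All three share one core and differ only in the group on the aromatic nitrogen. Compound 3, with an ethoxycarbonyl there, is separated from compound 2 by a 1.8-fold lower number from compound 2 to compound 3 (0.24 log units; within the scatter), so those two cannot be told apart on these numbers. Both stand clearly apart from compound 1: a 5.1-fold lower number from compound 1 to compound 3 (0.71 log units; beyond the scatter) and a 2.9-fold lower number from compound 1 to compound 2 (0.46 log units; beyond the scatter), each beyond the scatter, so a carbonyl attached to that nitrogen goes with a lower number than the cyclopropylmethyl.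

Compound 4 is `CCCCCCNC(=O)n1cc(F)c(=O)n(C(=O)OCC(C)C)c1=O`. Relative to compound 3 the change is isopropyl in place of methyl on a saturated chain carbon bound to an oxygen next to a carbonyl group. Among the measured compounds shown here, no measured step alters this chain; the only step that touches the carbonyl side is the swap of isopropyl for ethoxy on the carbonyl carbon, a 1.8-fold lower number from compound 2 to compound 3 (0.24 log units; within the scatter), which stayed within the scatter. That step suggests the assay tolerates variation out here, but it does not test the chain itself, so the expectation rests on little. Compound 4 is therefore expected to land close to compound 3, with a step of a 1.2-fold higher number from compound 3 to compound 4 (0.07 log units; within the scatter) that is not beyond the scatter. The estimate for compound 4 in this assay is 14 nM, with a range from 5 nM to 40 nM.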

Compound 4, half-maximal inhibitory concentration: 16 nM
For compound 4 the middle estimate is 1.1-fold (0.06 log units) below the measured one, and the stated range covers the measured number.
By their numbers in this assay, from the lowest: compounds 3, 4 and 2 (each within the scatter of the next); then compound 1.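

Among the compounds shown here, replacing methyl with isopropyl on a saturated chain carbon bound to an oxygen next to a carbonyl group tests the chain itself for the first time, and in this assay this change, which turns ethoxycarbonyl into isobutoxycarbonyl, gives a 1.3-fold higher number from compound 3 to compound 4 (0.12 log units; within the scatter), so the two compounds cannot be told apart. Swapping the isopropyl on the carbonyl carbon for isobutoxy likewise leaves no readable difference, at a 1.3-fold lower number from compound 2 to compound 4 (0.12 log units; within the scatter), whereas the comparison with the cyclopropylmethyl group remains clear, at a 3.8-fold lower number from compound 1 to compound 4 (0.58 log units; beyond the scatter), so the larger isobutoxycarbonyl group keeps the separation already seen for the other two carbonyl groups. No supporting measurement is available to explain why the assay shows so little response to this larger chain.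

On these data alone, how far this tolerance extends remains open, since a much longer chain such as octyloxy, a benzyloxy group carrying a ring, or an amine on the carbonyl carbon could give a different result. The four compounds also share the same hexyl chain and fluorine, so they cannot show how much either of these groups matters.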